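The source may hold more compounds than are shown below. What is called first, only, known or untested is meant among the compounds shown, and "the series" means these compounds.

Working notes on a small set of unsaturated lactones. Compound 1 `CCCC[C@@H](/C=C\[C@@H]1OC(=O)C=C[C@@H]1O)OC(C)=O` gives 2.2 ug/mL in a functional assay on P388 cells (Mus musculus) for cytotoxicity, read by sulforhodamine B assay, with a stated time of 48 h (on this read-out lower numbers stand for an effect already at smaller amounts and higher numbers for an effect only at larger amounts of compound), and so holds the higher of the two numbers in hand; compound 3 `CC(=O)O[C@H](/C=C\[C@H]1CC=CC(=O)O1)C[C@@H](OC(C)=O)[C@H](C)OC(C)=O` gives 1.6 ug/mL in this assay, a gap that lies within the scatter, so no order between the two is claimed. Compound 2 `CCCC[C@@H](/C=C\[C@@H]1OC(=O)C[C@@H](OC)[C@@H]1O)OC(C)=O` returns only a limit in this assay, > 5 ug/mL. Compound 4 `CCCC[C@@H](/C=C\[C@@H]1OC(=O)C=C[C@@H]1OC(C)=O)OC(C)=O` is not yet measured. Relative to compound 1 it differs by acetyl in place of hydrogen on an oxygen on a saturated carbon. Going by the values given here, no measured pair shows this hydroxy to acetoxy change, and the step of a 1.1-fold lower number from compound 1 to compound 4 (0.04 log units; within the scatter) is expected to stay within the scatter, in no firm direction. Compound 4 is accordingly estimated at 2 ug/mL in this assay, with a range from 0.8 ug/mL to 5 ug/mL.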

Compound 4, concentration for half-maximal effect: 0.9 ug/mL
Beside the measured number, compound 4's estimate is 2.2-fold (0.35 log units) above it; measured number inside the range.
By their numbers in this assay, from the lowest: compounds 4, 3 and 1 (each within the scatter of the next, the first and the last beyond it). At a limit, above all of these: compound 2.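

In this assay, going by these compounds alone, the hydroxy to acetoxy change gives a 2.4-fold lower number from compound 1 to compound 4 (0.39 log units; beyond the scatter) as the first reading at this place, on an oxygen on a saturated carbon. The hydrogen on that oxygen is therefore not required for the effect, and the acetyl is tolerated with a modest gain. Nothing at hand gives a cause for this step.

Going by these compounds, whether a longer acyl chain or a carbamate at this oxygen would follow the acetyl stays open. On these data alone, the part played by the second acetoxy, shared by compound 1 and compound 4, also stays open.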